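Bromo for chloro across two cores

The compounds below may be only part of what the source reports. "The series", "measured", "known", "first", "only" and "open" are said of these compounds alone.

Compound 1 `Fc1ccc(CNc2nc(Nc3cc(C4CC4)[nH]n3)c3cc(Cl)ccc3n2)c(F)c1` gives 72 nM in an assay for inhibition of high affinity nerve growth factor receptor (Homo sapiens), read by HTRF, with a stated time of 30 min, in the presence of a further agent that is not named here; on this read-out higher numbers stand for weaker inhibition and lower numbers for stronger inhibition. Compound 2 `Fc1ccc(CNc2nc(Nc3cc(C4CC4)[nH]n3)c3cc(Br)ccc3n2)c(F)c1` differs from it by bromo in place of chloro on an aromatic carbon and gives 120 nM; the step is a 1.7-fold higher number from compound 1 to compound 2 (0.22 log units; within the scatter). Compound 3 `Cc1cc(Nc2nc(NCc3ccc(F)cc3F)nc3cc(Cl)ccc23)n[nH]1` rests on a different core; the difference between the two cores is not broken down here. Compound 3 gives 15 nM in this assay, the lowest of the three numbers, with compound 1 and compound 2 beyond the scatter from it. Compound 4 `Cc1cc(Nc2nc(NCc3ccc(F)cc3F)nc3cc(Br)ccc23)n[nH]1` is not yet measured; it differs from compound 3 by bromo in place of chloro on an aromatic carbon, the same change as from compound 1 to compound 2 at a place described in the same words. Among the compounds with values here, the step from compound 3 to compound 4 in this assay is expected to be a 1.7-fold higher number from compound 3 to compound 4 (0.22 log units; within the scatter), resting on the single earlier step of a 1.7-fold higher number from compound 1 to compound 2 (0.22 log units; within the scatter). Compound 4 is estimated at 25 nM, between 10 nM and 60 nM.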

Compound 4, half-maximal inhibitory concentration: 53 nM
The estimate for compound 4 lay 2.1-fold (0.33 log units) below the measured number, within the range that was stated.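

On the core of compound 3, bromo in place of chloro on an aromatic carbon gives a 3.5-fold higher number from compound 3 to compound 4 (0.55 log units; beyond the scatter) in this assay. Set beside the step on the core of compound 1, this step does not differ from it by more than the scatter, so the change carries over between these two cores: the same change on two cores in this assay, a 1.7-fold higher number (0.22 log units; within the scatter) from compound 1 to compound 2 and a 3.5-fold higher number (0.55 log units; beyond the scatter) from compound 3 to compound 4, 2.1-fold (0.33 log units) apart, within the scatter of two such steps This does not show that the step has one fixed size, and two cores give no basis for predicting it on a further core.

Left open is what a group other than these two halogens, such as fluoro, methoxy or an amine, would do at this place.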